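Imide nitrogen substitution in the indolyl pyrazolopyridine series

The source may hold more compounds than are shown below. What is called first, only, known or untested is meant among the compounds shown, and "the series" means these compounds.

Measured so far:
compound 1 `Cn1cc(C2=C(c3nn(CCCCn4ccnc4)c4ncccc34)C(=O)NC2=O)c2ccccc21` — > 100000 nM
compound 2 `CN1CCN(CCCn2nc(C3=C(c4cn(C)c5ccccc45)C(=O)NC3=O)c3cccnc32)CC1` — > 100000 nM

In a functional assay on KB cells (Homo sapiens) for antiproliferative activity, read by MTT assay, with a stated time of 48 h (on this read-out higher numbers stand for weaker inhibition and lower numbers for stronger inhibition), compound 1 gives > 100000 nM, which is a limit of the assay and not a number. Compound 2 gives > 100000 nM in this assay, likewise a limit. The step that the two limits leave unreadable from compound 1 to compound 2 cannot be read because of the limit of > 100000 nM in this assay, at which 2 of the 2 values shown sit. Compound 1 therefore stands at the limit, with no measured number of its own and no measured neighbour whose value lies inside the readable range.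

Compound 3 `Cn1cc(C2=C(c3nn(CCCCn4ccnc4)c4ncccc34)C(=O)N(c3ccccc3)C2=O)c2ccccc21` differs from compound 1 by phenyl in place of hydrogen on an amide-type nitrogen in a ring. Going by the values given here, no measured step bears on this position: the only measured step, a step that the two limits leave unreadable from compound 1 to compound 2, concerns another place on the molecule and is itself unreadable. The data thus give no direction for the change, and nothing supports a move into the readable range. Compound 3 is expected to sit near the same limit, at an estimated 100000 nM with a range from 20000 nM to 300000 nM. Among the compounds with values here, this estimate corresponds to an expected step of a number no higher from compound 1 to compound 3 (the limit leaves the size open), that is, no step that the scatter would reveal.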

Compound 3, half-maximal inhibitory concentration: 47300 nM
Compound 3: middle estimate off by 2.1-fold (0.33 log units), on the high side, and the stated range covers the measured number.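

Phenyl in place of hydrogen on the amide-type nitrogen of the five-membered non-aromatic ring gives, in this assay, an at least 2.1-fold lower number from compound 1 to compound 3 (0.32 log units; beyond the scatter). At 47300 nM, compound 3 is the only compound shown with a measured number, so this nitrogen is the one place in the series where a change is seen to bring a value inside the readable range, and it accepts a group as large as phenyl with the value staying inside that range. The step has only a lower bound on its size, and how far it reaches stays open because compound 1 has no number of its own: the limit of > 100000 nM in this assay, at which 2 of the 3 values shown sit.

Going by these compounds, whether the shift belongs to the phenyl ring itself or to any substituent on this nitrogen stays open, and a methyl or a benzyl group on the same nitrogen would separate the two. On these data alone, the step between the two side chains cannot be read, so it also remains open whether phenyl on this nitrogen would act the same way with the 4-methylpiperazin-1-yl chain of compound 2.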